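Perfluoroalkyl chain length in a nitrone series

This account rests on a few compounds, and the source may have more. Where it says the series, first, only, none or still open, it means among the compounds named here.

Measured so far:
compound 1, `[O-]/[N+](=C\c1cn(CCC(F)(F)C(F)(F)C(F)(F)C(F)(F)C(F)(F)C(F)(F)C(F)(F)C(F)(F)F)nn1)c1ccccc1` — 86800 nM
compound 2, `CCCCCCCCCCn1cc(/C=[N+](\[O-])Cc2ccccc2)nn1` — > 100000 nM
compound 3, `[O-]/[N+](=C\c1cn(CCC(F)(F)C(F)(F)C(F)(F)C(F)(F)C(F)(F)C(F)(F)F)nn1)Cc1ccccc1` — > 100000 nM

All three were read in a functional assay on A549 cells (Homo sapiens) for inhibition, read by MTT assay, with a stated time of 24 h; on this read-out higher numbers stand for weaker inhibition and lower numbers for stronger inhibition. For compound 3 the value is a limit of the assay and not a number. For compound 2 the value is likewise a limit. Compound 1 is the only one of the three that gives a number in this assay. Among the measured compounds shown here, compound 3 therefore stands at the limit, with one further value among those shown sitting there as well, so it cannot be ordered against compound 2; it differs from compound 1 in more than one place, and no single-change step between measured compounds exists in this set.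

Compound 4, `[O-]/[N+](=C\c1cn(CCC(F)(F)C(F)(F)C(F)(F)C(F)(F)C(F)(F)C(F)(F)C(F)(F)C(F)(F)F)nn1)Cc1ccccc1`, is not yet measured. It differs from compound 3 by 1,1,2,2,2-pentafluoroethyl in place of fluoro on a saturated chain carbon bound to two fluorine atoms and a saturated chain carbon.

For the measured compounds named here, with no measured step to lean on, no change beyond the usual scatter is expected from compound 3 to compound 4 in this assay, because the limit of > 100000 nM in this assay, at which 2 of the 3 values shown sit, places most of the series at the edge of what the assay can resolve. Compound 4 is accordingly estimated at 100000 nM, within 50000 nM to 250000 nM, and the expected step is a number no higher from compound 3 to compound 4 (the limit leaves the size open).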

Compound 4, half-maximal inhibitory concentration: 8800 nM
Estimate against measurement, compound 4: 11-fold (1.06 log units) above; the measured number lies below the stated range.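

In this assay compound 3 gives > 100000 nM, which is a limit of the assay and not a number. Among the compounds shown here, the change at this position, 1,1,2,2,2-pentafluoroethyl in place of fluoro on a saturated chain carbon bound to two fluorine atoms and a saturated chain carbon, gives an at least 11-fold lower number from compound 3 to compound 4 (1.05 log units; beyond the scatter) and is the first single change to bring a benzyl compound off the limit, though the full size of the step stays open: the limit of > 100000 nM in this assay, at which 2 of the 4 values shown sit. With the longer perfluoroalkyl chain held constant, benzyl in place of phenyl on a double-bonded nitrogen gives a 9.9-fold lower number from compound 1 to compound 4 (0.99 log units; beyond the scatter), so in this assay the read-out moves with a change at either of these two places.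

Going by these compounds, whether a perfluoroalkyl chain longer than that of compound 4 would lower the number further remains open, as does the effect of an amine or a carboxylic acid at the end of the chain. The phenyl and benzyl comparison rests on the longer chain alone, so whether it holds with the shorter chain of compound 3 cannot be told from these compounds.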